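Removing the 4-chlorophenyl group from compound 2

This account rests on a few compounds, and the source may have more. Where it says the series, first, only, none or still open, it means among the compounds named here.

In an ADME assay on HepG2 cells (Homo sapiens) for cytotoxicity, read by MTT assay, with a stated time of 72 h (on this read-out lower numbers stand for higher toxicity in this test and higher numbers for lower toxicity in this test), compound 1 `Cc1ccc(-c2cc3nc(NCc4ccccc4Cl)[nH]c(=O)c3s2)cc1` gives 32600 nM and compound 3 `COc1ccc(-c2cc3nc(NC(C)C)[nH]c(=O)c3s2)cc1` gives 27100 nM. Compound 2 `CC(C)Nc1nc2cc(-c3ccc(Cl)cc3)sc2c(=O)[nH]1` gives > 15600 nM, which is a limit of the assay and not a number. Compound 2 thus stands at the limit of > 15600 nM in this assay, at which 1 of the 3 values shown sits.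

Compound 4 `CC(C)Nc1nc2ccsc2c(=O)[nH]1` differs from compound 2 in one place: hydrogen in place of 4-chlorophenyl on an aromatic carbon. In words, this is hydrogen in place of 4-chlorophenyl on an aromatic carbon.

For the measured compounds named here, only one measured step starts from compound 2, namely a step that the limit leaves unreadable from compound 2 to compound 3, with methoxy in place of chloro on an aromatic carbon. Going by the values given here, it gives no size to carry over, and no measured compound lacks the aryl group. The expectation therefore rests on the values themselves, with compound 3 at 27100 nM as the closest numerical guide. In this assay, the expected change is a step that the limit leaves unreadable from compound 2 to compound 4, tentatively toward lower toxicity in this test. For compound 4, the estimated value is 45000 nM, with an expected range from 15000 nM to 130000 nM.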

Compound 4, half-maximal cytotoxic concentration: 23900 nM
Estimate against measurement, compound 4: 1.9-fold (0.27 log units) above; the measured number falls inside the stated range.
By their numbers in this assay, from the lowest: compounds 4, 3 and 1 (each within the scatter of the next).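

No step can be read from compound 2 to compound 4, because compound 2 is held only by a limit of the assay and not by a number: the limit of > 15600 nM in this assay, at which 1 of the 4 values shown sits. The compounds shown leave open what replacing the 4-chlorophenyl group with hydrogen does to cytotoxicity.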